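A few compounds are considered here, and "the series" means these few. Any claim that something is new, unique, unknown or untested is made for them only; others in the source may bear on it.

Measured so far:
- compound 1 `CC(C)(C)[C@H]1CC[C@H](N(C(=O)Nc2ccc(OC(F)(F)F)cc2)C2CCOc3cc(C(=O)Nc4nn[nH]n4)ccc32)CC1`: 76 nM; 0.5 nM (2 entries)
- compound 2 `CC(C)(C)[C@H]1CC[C@H](N(C(=O)c2ccc(OC(F)(F)F)cc2)C2CCc3cc(C(=O)NCCC(=O)O)ccc32)CC1`: 130 nM

Within the data shown here, in an assay on CHO cells for displacement of a labelled ligand from Glucagon receptor (Homo sapiens) (a higher number here means a weaker inhibitor, a lower number a stronger inhibitor), compound 2 gives 130 nM, the only number it has there, with one further entry that is not a single number. Compound 1 has several entries the several entries of compound 1 in this assay, 76 nM; 0.5 nM (2 entries) that lie far apart.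

Compound 3 `CC(C)(C)[C@H]1CC[C@H](N(C(=O)Nc2cc(Cl)cc(Cl)c2)C2CCc3cc(C(=O)NCCC(=O)O)ccc32)CC1` differs from compound 2 by (3,5-dichlorophenyl)amino in place of 4-(trifluoromethoxy)phenyl on a carbonyl carbon. Among the measured compounds shown here, no step between measured compounds covers this change, so the size is open; a shift toward stronger binding, or none beyond the scatter, is expected. The expected step is a 2.2-fold lower number from compound 2 to compound 3 (0.34 log units; beyond the scatter). Compound 3 is estimated at 60 nM, within 15 nM to 300 nM.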

Compound 3, half-maximal inhibitory concentration: 10 nM
Compound 3: the middle estimate sits 6.0-fold (0.78 log units) above what was measured; measured number outside the range, below it.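

On the carbonyl carbon whose other neighbour is an amide-type nitrogen, (3,5-dichlorophenyl)amino in place of 4-(trifluoromethoxy)phenyl gives, in this assay, a 13-fold lower number from compound 2 to compound 3 (1.11 log units; beyond the scatter). Among these compounds, this is the only readable step, and it shows that binding responds strongly to the group at this place. Its size needs caution, since single numbers in this assay can spread widely: the several entries of compound 1 in this assay, 76 nM; 0.5 nM (2 entries)

From the compounds shown here alone, the step changes the ring substituents and adds the amino link together, so the share of each stays open. Plain phenylamino, or 3,5-dichlorophenyl directly on the carbonyl carbon, would separate them.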